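A few compounds are considered here, and "the series" means these few. Any claim that something is new, unique, unknown or untested is made for them only; others in the source may bear on it.

Working notes on the series.

Compound 1, `CCn1c(C(=O)N(C)CCC#N)ccc1C(CC)(CC)c1ccc(OCC(=O)C(C)(C)C)c(C)c1`, gives 9800 nM in an assay on HL-60 cells for agonist activity at vitamin D3 receptor (Homo sapiens), read by microscopy, with a stated time of 96 h; on this read-out higher numbers stand for an effect only at larger amounts of compound and lower numbers for an effect already at smaller amounts. Compound 2, `C=CCN(C)C(=O)c1ccc(C(CC)(CC)c2ccc(OCC(=O)C(C)(C)C)c(C)c2)n1CC`, gives 21600 nM in this assay; the change between them is vinyl in place of cyanomethyl on a saturated chain carbon bound to an amide-type nitrogen, and it made a 2.2-fold higher number from compound 1 to compound 2 (0.34 log units; beyond the scatter). Compound 3, `CCn1c(C(=O)N(C)CCC#N)ccc1C(CC)(CC)c1ccc(OCC(O)C(C)(C)C)c(C)c1`, gives 1960 nM in this assay, the lowest number of the three measured; against compound 1 its core differs by 1-hydroxy-2,2-dimethylpropyl in place of (tert-butyl)carbonyl on a saturated chain carbon bound to an oxygen on an aromatic ring, which made a 5.0-fold lower number from compound 1 to compound 3 (0.70 log units; beyond the scatter). Compound 2 and compound 3 are not compared as a single step here; their two values stand as given.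

Compound 4, `C=CCN(C)C(=O)c1ccc(C(CC)(CC)c2ccc(OCC(O)C(C)(C)C)c(C)c2)n1CC`, is not yet measured in this assay. It differs from compound 3 by vinyl in place of cyanomethyl on a saturated chain carbon bound to an amide-type nitrogen, the same change that turns compound 1 into compound 2, on the same place. Among the compounds with values here, the expectation is that compound 4 repeats that step on the core of compound 3: the estimated step is a 2.2-fold higher number from compound 3 to compound 4 (0.34 log units; beyond the scatter), resting on the one measured instance of this change, a 2.2-fold higher number from compound 1 to compound 2 (0.34 log units; beyond the scatter), and on the value of compound 3, 1960 nM. Within the data shown here, with only one prior instance, the expected range is kept wide. Compound 4 is therefore estimated at 4300 nM, between 1800 nM and 10000 nM.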

Compound 4, half-maximal effective concentration: 3950 nM
Compound 4: middle estimate off by 1.1-fold (0.04 log units), on the high side; measured number inside the range.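

In this assay vinyl in place of cyanomethyl gives a 2.0-fold higher number from compound 3 to compound 4 (0.30 log units; within the scatter) and so carries over to the second core at the size seen on the first: the same change on two cores in this assay, a 2.2-fold higher number (0.34 log units; beyond the scatter) from compound 1 to compound 2 and a 2.0-fold higher number (0.30 log units; within the scatter) from compound 3 to compound 4, 1.1-fold (0.04 log units) apart, within the scatter of two such steps. Read the other way through the same four compounds, 1-hydroxy-2,2-dimethylpropyl in place of (tert-butyl)carbonyl gives a 5.5-fold lower number from compound 2 to compound 4 (0.74 log units; beyond the scatter) and also keeps its size from one core to the other: the same change on two cores in this assay, a 5.0-fold lower number (0.70 log units; beyond the scatter) from compound 1 to compound 3 and a 5.5-fold lower number (0.74 log units; beyond the scatter) from compound 2 to compound 4, 1.1-fold (0.04 log units) apart, within the scatter of two such steps. This shows that within these four compounds each change can be carried between the two cores, but each comparison rests on a single pair of steps, so it shows neither that this holds on any further core nor why the steps behave this way.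

The compounds shown leave open whether a longer chain or a carboxylic acid, on a saturated chain carbon bound to an amide-type nitrogen, would follow the vinyl and cyanomethyl results. They also leave open whether an amine in place of the 1-hydroxy-2,2-dimethylpropyl would give a step that carries over in the same way.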